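Alkyl Amide Chain in Place of Benzyl Amide

The source may report more compounds than this note shows. Statements on the series, on what has been measured and on what is new or still open speak of the compounds shown alone.

The series shares the core seen in compound 1 `COCCNC(=O)C1CCN(c2nc(N)c3cc(OC)c(OC)cc3n2)CC1`, which in an assay on isolated protein for displacement of a labelled ligand from Adrenergic receptor alpha-1 (Rattus norvegicus) (on this read-out lower numbers stand for stronger inhibition and higher numbers for weaker inhibition), gives 1.13 nM. Compound 2 `COc1cc2nc(N3CCC(C(=O)Nc4ccccc4)CC3)nc(N)c2cc1OC` gives 0.47 nM in this assay, and compound 3 `COc1cc2nc(N3CCC(C(=O)NCc4ccccc4)CC3)nc(N)c2cc1OC` gives 0.22 nM. Compound 3 holds the lowest number of the three measured compounds; the nearest is compound 2 and the furthest is compound 1. Among the measured steps, a 2.4-fold lower number from compound 1 to compound 2 (0.38 log units; beyond the scatter) and a 5.1-fold lower number from compound 1 to compound 3 (0.71 log units; beyond the scatter) both replace an open-chain group with an aromatic ring, and a 2.1-fold lower number from compound 2 to compound 3 (0.33 log units; beyond the scatter) separates the two aromatic amides.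

Compound 4 `CCCCNC(=O)CCC1CCN(c2nc(N)c3cc(OC)c(OC)cc3n2)CC1` is the unmeasured member. Relative to compound 3 the change is 2-(butylcarbamoyl)ethyl in place of benzylcarbamoyl on a saturated ring carbon. This removes the aromatic ring that the steps from compound 1 to compound 2 and from compound 1 to compound 3 rewarded, and puts a chain amide in its place, much as compound 1 carries a chain amide. The step of a 5.1-fold lower number from compound 1 to compound 3 (0.71 log units; beyond the scatter) bears most directly on this, running in the opposite direction. Compound 4 is therefore expected to return a higher number in this assay, in the vicinity of compound 1, with a 4.5-fold higher number from compound 3 to compound 4 (0.66 log units; beyond the scatter) as the expected step. The estimate for compound 4 is 1 nM, within a range from 0.3 nM to 3.5 nM.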

Compound 4, inhibition constant: 0.47 nM
Estimate against measurement, compound 4: 2.1-fold (0.33 log units) above; the range from low to high includes it.
By their numbers in this assay, from the lowest: compound 3; then compounds 2 and 4 (each within the scatter of the next); then compound 1.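

In this assay the group on the saturated ring carbon need not contain a ring to give a number in the range of the aromatic amides: set against phenylcarbamoyl, 2-(butylcarbamoyl)ethyl shows no separation (no change at the digits printed from compound 2 to compound 4 (within the scatter)). Against the open-chain (2-methoxyethyl)carbamoyl it also gives a lower number (a 2.4-fold lower number from compound 1 to compound 4 (0.38 log units; beyond the scatter)), so two open-chain amides can differ beyond the scatter, and the earlier link between an aromatic ring and a lower number does not hold for all four compounds, with compound 4 going against it. Benzylcarbamoyl still keeps an edge over the butyl chain amide (a 2.1-fold higher number from compound 3 to compound 4 (0.33 log units; beyond the scatter)), and no supporting data bear on why any of these groups reads as it does.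

On these data alone, what stays open is how much of this belongs to the ethyl link and how much to the butyl chain on the amide nitrogen, since compound 4 differs from the other compounds in both at once. A 2-(benzylcarbamoyl)ethyl group would separate the two, while a hexyl chain on the amide nitrogen or an amine in place of the amide would show how far this position tolerates further change.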